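This account rests on a few compounds, and the source may have more. Where it says the series, first, only, none or still open, it means among the compounds named here.

Of the compounds shown here, two on a shared core have been measured so far in a functional assay on PC-3 cells (Homo sapiens) for inhibition, read by sulforhodamine B assay, with a stated time of 48 h; a higher number here means a weaker inhibitor of growth, a lower number a stronger inhibitor of growth. Compound 1 (`CCOC(=O)C1=C(C)NC(=S)NC1c1ccc(O)cc1`) gives 47.6 ug/mL, and compound 2 (`CCOC(=O)C1=C(C)NC(=O)NC1c1ccc(O)c(O)c1`) gives 18.2 ug/mL. Compound 2 therefore holds the lower of the two numbers, and its gap to compound 1 lies beyond the usual scatter. Among the compounds with values here, these two compounds differ in more than one place, so no single-change step between measured compounds is available as a guide.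

Compound 3 (`CCOC(=O)C1=C(C)NC(=O)NC1c1ccc(O)cc1`) comes from compound 2 by one change: hydrogen in place of hydroxy on an aromatic carbon. Hydrogen stands in place of hydroxy on an aromatic carbon, and the remaining hydroxy group stays. The change is expected to raise the number in this assay, giving a weaker inhibitor of growth. Within the data shown here, the only support is that compound 1, which also lacks this hydroxy, stands at 47.6 ug/mL, and this is thin evidence. The expected step, a 2.1-fold higher number from compound 2 to compound 3 (0.32 log units; beyond the scatter), is a moderate one, close to the edge of the scatter. For compound 3 the estimated value is 38 ug/mL, with an expected range from 16 ug/mL to 85 ug/mL.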

Compound 3, concentration for 50% growth inhibition: 136 ug/mL
Compound 3: middle estimate off by 3.6-fold (0.55 log units), on the low side; the measured number lies above the stated range.
By their numbers in this assay, from the lowest: compound 2; then compound 1; then compound 3.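

Within the data shown here, with hydrogen in place of hydroxy on an aromatic carbon, ortho to a hydroxy group and meta to a large group, this assay shows a 7.5-fold higher number from compound 2 to compound 3 (0.87 log units; beyond the scatter), the first step on the shared core that can be read at a single place, and it marks this position as one where the change matters for growth inhibition. The value of compound 1 had been a poor guide to this step: compound 1, which also lacks this hydroxy and carries a thiocarbonyl in place of the carbonyl, gives 47.6 ug/mL, whereas compound 3 gives 136 ug/mL, so a compound lacking the hydroxy group need not sit near compound 1. Nothing at hand explains the size of the step.

From the compounds shown here alone, it remains open whether the hydroxy group itself is required at this carbon, or whether a methoxy group, a fluorine atom or an amine there would keep the number as low as in compound 2. Also open, going by these compounds, is whether the same step would appear on the thiocarbonyl form of the core, as a partner of compound 1 carrying both hydroxy groups would show.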